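A Second Fluorine Enters a Flat Series

The source may report more compounds than this note shows. Statements on the series, on what has been measured and on what is new or still open speak of the compounds shown alone.

In a functional assay on PANC-1 cells (Homo sapiens) for inhibition, read by MTT assay, with a stated time of 24 h, tested at 10 uM (on this read-out lower numbers stand for less inhibition and higher numbers for more inhibition at the one concentration tested (going by the name of the read-out)), compound 3 `CC(C)=CCC1Cc2c(OC(=O)Nc3cccc(F)c3)cc(=O)n(CCCO)c2CC1(C)C` gives 0%. The two measured relatives sit at the same level: compound 1 `CC(C)=CCC1Cc2c(OCCCOc3ccc(Cl)cc3)cc(=O)n(CCCO)c2CC1(C)C` gives 0%, and compound 2 `CC(C)=CCC1Cc2c(OC(=O)Nc3ccc(F)cc3)cc(=O)n(CCCO)c2CC1(C)C` gives 0%. The steps of no change at the digits printed from compound 1 to compound 2 (within the scatter), no change at the digits printed from compound 1 to compound 3 (within the scatter) and no change at the digits printed from compound 2 to compound 3 (within the scatter) show that neither exchanging the whole side group nor changing where the fluorine sits on its ring moved the read-out beyond the scatter.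

Compound 4 `CC(C)=CCC1Cc2c(OC(=O)Nc3ccc(F)c(F)c3)cc(=O)n(CCCO)c2CC1(C)C` differs from compound 3 by fluoro in place of hydrogen on an aromatic carbon. The closest measured step is no change at the digits printed from compound 2 to compound 3 (within the scatter), which was flat. Going by the values given here, no measured pair adds a fluoro to a ring that already carries one, so the expectation rests on the flat picture alone. Compound 4 is therefore expected to give 0%, between 0% and 10%, an expected step of no change at the digits printed from compound 3 to compound 4 (within the scatter).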

Compound 4, a percentage reported as inhibition, at one concentration (the size of the read-out at that concentration, not a potency): 0%
Compound 4: middle estimate and measured number agree at the digits printed; measured number inside the range.
By their numbers in this assay, from the lowest: compounds 1, 2, 3 and 4 (each within the scatter of the next).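

In this assay, a second fluoro on the ring, ortho to a fluoro group and para to a large group, gives no change at the digits printed from compound 3 to compound 4 (within the scatter). The picture is the same when the fluoro is added to the other singly fluorinated ring, no change at the digits printed from compound 2 to compound 4 (within the scatter), and when the (3,4-difluorophenyl)carbamoyl group replaces the 3-(4-chlorophenoxy)propyl group, no change at the digits printed from compound 1 to compound 4 (within the scatter).

Because all four compounds sit level, the series cannot show whether another group on this ring, such as an amine or a carboxylic acid, would move the read-out. No supporting measurement bears on this flat result.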